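This account rests on a few compounds, and the source may have more. Where it says the series, first, only, none or still open, it means among the compounds named here.

Of the compounds shown here, three that share a core have been measured so far in a physicochemical assay for solubility, read by nephelometry, measured as kinetic solubility; on this read-out lower numbers stand for lower solubility and higher numbers for higher solubility. Compound 1 (`CCC/N=C1\S/C(=C\c2ccc(C(=O)OCCO)cc2)C(=O)N1c1ccccc1C`) gives 110000 nM, and compound 2 (`CCC/N=C1\S/C(=C\c2ccc(OC[C@H](O)CO)c(Cl)c2)C(=O)N1c1ccccc1O`) gives 219000 nM. Compound 3 (`CCC/N=C1\S/C(=C\c2ccc(C(=O)OCCCO)cc2)C(=O)N1c1ccccc1O`) gives 183000 nM, which lies within the usual scatter of both other numbers, so these three results cannot be ranked.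

Compound 4 (`CCC/N=C1\S/C(=C\c2ccc(CCC(=O)OC)cc2)C(=O)N1c1ccccc1O`) has not yet been measured. It differs from compound 3 in one place, on an aromatic carbon of a six-membered aromatic ring of carbon only, para to a large group: 2-(methoxycarbonyl)ethyl stands in place of (3-hydroxypropoxy)carbonyl (2-(methoxycarbonyl)ethyl in place of (3-hydroxypropoxy)carbonyl on an aromatic carbon).

Within the data shown here, no two measured compounds differ in just one place, so the data give no direct measure of what a single change does here, and any forecast is tentative. One observation offers a weak guide. Compound 3, at 183000 nM, carries a side chain ending in a hydroxyl, as do the other two measured compounds, whereas the new side chain has none. In this assay a modest fall is therefore expected, only a little beyond the scatter, and the estimate is a 2.3-fold lower number from compound 3 to compound 4 (0.36 log units; beyond the scatter). For compound 4 the estimated value is 80000 nM, with an expected range from 30000 nM to 170000 nM.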

Compound 4, solubility: 79000 nM
Estimate against measurement, compound 4: 1.0-fold (0.01 log units) above; measured number inside the range.
By their numbers in this assay, from the lowest: compounds 4, 1, 3 and 2 (each within the scatter of the next, the first and the last beyond it).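

Among these compounds, compound 3 and compound 4 form the first pair here that differs in one place, so this is the first direct reading of a single change on the shared core. In this assay, putting 2-(methoxycarbonyl)ethyl in place of (3-hydroxypropoxy)carbonyl on an aromatic carbon, para to a large group, gives a 2.3-fold lower number from compound 3 to compound 4 (0.36 log units; beyond the scatter), which shows that a change at this position can move the number beyond the usual scatter, though only modestly. Several things change together in this swap, since the group that leaves has 1 hydrogen-bond donor and 3 hydrogen-bond acceptors and the one that enters has 0 hydrogen-bond donors and 2 hydrogen-bond acceptors, and no outside measurement says which of these differences matters.

Among the compounds shown here, the single step therefore cannot separate the loss of the hydroxyl from the other differences between the two groups, and a pair such as 3-hydroxypropyl set against 2-(methoxycarbonyl)ethyl would be needed to pull them apart. From the compounds shown here alone, how a carboxylic acid, an amine or a longer chain would read at this position remains open, as does whether the step keeps its size when the rest of the molecule differs.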